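Aryl fluorine pattern on compound 2: difluoro analogue

This account rests on a few compounds, and the source may have more. Where it says the series, first, only, none or still open, it means among the compounds named here.

Compound 2 `N#Cc1c(N2CCC(c3cccc(F)c3)CC2)ccn(CC2CC2)c1=O` gives 141 nM in a functional assay on CHO cells for positive allosteric modulation of metabotropic glutamate receptor 2 (Homo sapiens), with a stated time of 30 min; on this read-out lower numbers stand for an effect already at smaller amounts and higher numbers for an effect only at larger amounts of compound. Among the three measured members it holds the second highest number: its nearest neighbour, compound 3 `N#Cc1c(N2CCC(c3cccc(C(F)(F)F)c3)CC2)ccn(CC2CC2)c1=O`, gives 46 nM, while the furthest of the set, compound 1 `CC(C)CCn1ccc(N2CCN(c3ccccc3)CC2)c(C#N)c1=O`, gives 661 nM. For the measured compounds named here, the only single-point step recorded is a 3.1-fold lower number from compound 2 to compound 3 (0.49 log units; beyond the scatter); it shows that the group carried by the phenyl on the saturated ring carbon moves the read-out beyond the scatter, in the direction of a lower number.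

Compound 4 `N#Cc1c(N2CCC(c3c(F)cccc3F)CC2)ccn(CC2CC2)c1=O` has not yet been measured. It differs from compound 2 by 2,6-difluorophenyl in place of 3-fluorophenyl on a saturated ring carbon. Going by the values given here, no measured pair mirrors this change: the step from compound 2 to compound 3 concerns trifluoromethyl in place of fluoro, not a second fluorine, and compound 1 differs from compound 2 at more than one place, so only its value stands beside that of compound 2. The step from compound 2 to compound 3 sets the scale of what a change on this phenyl can do, so a shift of modest size is possible in either direction; no shift beyond the scatter is expected in this assay, the expected step being a 1.1-fold higher number from compound 2 to compound 4 (0.03 log units; within the scatter). For compound 4 the estimated value is 150 nM, with a range from 50 nM to 500 nM.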

Compound 4, half-maximal effective concentration: 31 nM
Estimate against measurement, compound 4: 4.8-fold (0.68 log units) above, outside the stated range (below it).
By their numbers in this assay, from the lowest: compounds 4 and 3 (each within the scatter of the next); then compound 2; then compound 1.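

In this assay, for the compounds shown here, the exchange of 3-fluorophenyl for 2,6-difluorophenyl on a saturated ring carbon gives a lower number beyond the scatter (a 4.5-fold lower number from compound 2 to compound 4 (0.66 log units; beyond the scatter)), so trifluoromethyl is not the only change on this phenyl that lowers the read-out, and a phenyl carrying only fluorine can do so as well. Compound 3 gives 46 nM and compound 4 gives 31 nM as values within the scatter of each other, which places the trifluoromethyl and 2,6-difluoro patterns at one level on the read-out. No measurement at hand bears on the reason for the lower number of compound 4.

The step from compound 2 changes the count of fluorine atoms and their placement together, so the compounds shown do not tell which of the two accounts for the lower number. Also open, from the compounds shown here alone, are whether other groups on this phenyl, such as chloro or methoxy, reach the same level, and whether the 2,6-difluorophenyl gain holds when a longer chain replaces the cyclopropylmethyl group.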